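The source may report more compounds than this note shows. Statements on the series, on what has been measured and on what is new or still open speak of the compounds shown alone.

Of the compounds shown here, three have been measured in an assay on RPMI-8226 cells for antagonist activity at P2X purinoceptor 7 (Homo sapiens), read by calcium flux (a lower number here means a stronger inhibitor, a higher number a weaker inhibitor), and one more waits for its number. Compound 1, with the structure `O=c1[nH]c2ccccc2n1CCCN1CCC(=C(c2ccccc2)c2ccccc2)CC1`, gives 2400 nM in this assay. Compound 2, with the structure `O=c1[nH]c2ccccc2n1C/C=C/CN1CCN(C(c2ccccc2)c2ccccc2)CC1`, reaches only a limit of the assay in this assay, > 10000 nM, rather than a number; (the limit of > 10000 nM in this assay, at which 1 of the 3 values shown sits). Compound 3, with the structure `Cc1cccc2c1ccn2CCCCN1CCN(C(c2ccccc2)c2ccccc2)CC1`, gives 5300 nM in this assay, which is the higher of the two numbers recorded, and its gap to compound 1 lies beyond the usual scatter of this kind of measurement.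

Compound 4, with the structure `Fc1cc2ccn(CCCCN3CCN(C(c4ccccc4)c4ccccc4)CC3)c2cc1F`, has not yet been measured. It differs from compound 3 in one place: a group of 11 heavy atoms (8 carbon, 1 nitrogen, 2 fluorine; one five-membered aromatic ring with 1 hetero atom, one six-membered aromatic ring of carbon only) in place of a group of 10 heavy atoms (9 carbon, 1 nitrogen; one five-membered aromatic ring with 1 hetero atom, one six-membered aromatic ring of carbon only), on a saturated chain carbon, four bonds along the chain from an amine nitrogen in a ring. The five-membered aromatic ring with its one hetero atom and the six-membered aromatic ring of carbon only are kept, and the two fluorine atoms take the place of one carbon, at the same point along the saturated chain from the amine nitrogen in the ring. Among the compounds with values here, no pair of measured compounds differs in the same way, so the size of this step cannot be read off from the data.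

The step from compound 3 to compound 4 is therefore expected to be small, a 1.3-fold lower number from compound 3 to compound 4 (0.12 log units; within the scatter), with no direction established beyond the scatter. Compound 4 is estimated at 4000 nM in this assay, within the range 1500 nM to 10000 nM.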

Compound 4, half-maximal inhibitory concentration: 130 nM
Beside the measured number, compound 4's estimate is 31-fold (1.49 log units) above it, and the stated range ends above it.
By their numbers in this assay, from the lowest: compound 4; then compound 1; then compound 3. At a limit, above all of these: compound 2.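

In this assay, the group on the saturated chain carbon, four bonds along the chain from an amine nitrogen in a ring, turns out to matter a great deal: keeping its two aromatic rings while two fluorine atoms enter and one carbon leaves gives a 41-fold lower number from compound 3 to compound 4 (1.61 log units; beyond the scatter). Within the data shown here, the earlier compounds could not show this, as no two of them differ in one place, so the first reading of any change at this position comes from this pair. Nothing measured here explains the size of this step.

With both changes made in a single step, the compounds shown do not separate the effect of the two fluorine atoms from the loss of the carbon, and they do not tell whether one fluorine atom alone would give a similar result. They also leave open whether a chlorine atom or a nitrile in the same group would do the same, and whether the step would hold on a shorter chain.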